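A few compounds are considered here, and "the series" means these few. Any claim that something is new, unique, unknown or untested is made for them only; others in the source may bear on it.

Compound 3 `CN(C)C(=O)c1ccncc1Nc1cc(-c2ccc3ccn(C)c3c2)c2nccnc2c1` in an ADME assay on microsomes from liver (Mus musculus, strain CD-1) for metabolic stability, read by LC-MS, tested at 2 uM (a lower number here means that the compound disappears faster, a higher number that the compound lasts longer), gives 0.35 h. Among the compounds with values here, of the three numbers measured so far it is the second highest, yet both neighbouring gaps lie within the scatter: compound 1 `Cn1ccc2ccc(-c3cc(Nc4ccccc4S(N)(=O)=O)cc4nccnc34)cc21` gives 0.5 h and compound 2 `CN(C)S(=O)(=O)c1ccccc1Nc1cc(-c2ccc3ccn(C)c3c2)c2nccnc2c1` gives 0.233 h. Compound 4 `CN1CC(NC(=O)c2ccncc2Nc2cc(-c3ccc4ccn(C)c4c3)c3nccnc3c2)CCC1=O` has not been measured; it differs from compound 3 in one place: (1-methyl-6-oxopiperidin-3-yl)amino in place of dimethylamino on a carbonyl carbon. Within the data shown here, the only measured step, a 2.1-fold lower number from compound 1 to compound 2 (0.33 log units; beyond the scatter), changes a group on a sulfonyl sulfur rather than on a carbonyl carbon, so it bears only loosely on the present change, and no measured pair shows an amide hydrogen entering. Compound 4 is therefore expected to give 0.4 h, between 0.2 h and 0.8 h, an estimated step of a 1.1-fold higher number from compound 3 to compound 4 (0.06 log units; within the scatter), no larger than the scatter.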

Compound 4, half-life: 0.75 h
The estimate for compound 4 lay 1.9-fold (0.27 log units) below the measured number; measured number inside the range.
By their numbers in this assay, from the lowest: compounds 2, 3, 1 and 4 (each within the scatter of the next, the first and the last beyond it).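

On the carbonyl carbon, the group attached through nitrogen clearly matters in this assay: placing (1-methyl-6-oxopiperidin-3-yl)amino where dimethylamino stood gives a 2.1-fold higher number from compound 3 to compound 4 (0.33 log units; beyond the scatter) and so shows that this position accepts a much larger group bearing a ring and an amide hydrogen with no loss of half-life. Here, as on the sulfonyl sulfur in the earlier step, the compound with dimethylamino has the lower number. Nothing available explains this rise. Still open, on these data alone, is whether the ring or the amide hydrogen carries the change, and whether a plain methylamino group or a morpholine ring on the same carbonyl carbon would behave alike.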